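Notes on the step from compound 2 to compound 3

The compounds below may be only part of what the source reports. "The series", "measured", "known", "first", "only" and "open" are said of these compounds alone.

Measured so far in a functional assay on the whole organism (strain Kunming) with Mus musculus as the target, in the formalin test, with a stated time of 0.5 h; on this read-out higher numbers stand for an effect only at larger amounts of compound and lower numbers for an effect already at smaller amounts:
- compound 1 `COc1ccccc1/C=C/C(=O)OC/C=C/c1cc(OC)c(OC)cc1OC` gives 294 umol/kg
- compound 2 `COc1cc(OC)c(OC)cc1/C=C/COC(=O)/C=C/c1cccc(Br)c1` gives 260 umol/kg

For the measured compounds named here, with only two numbers in hand, compound 2 cannot be ranked against compound 1 (the step is a 1.1-fold lower number from compound 1 to compound 2 (0.05 log units; within the scatter) and so gives no order). The next compound is compound 3 `COc1cc(OC)c(OC)cc1/C=C/COC(=O)/C=C/c1ccccc1Cl`, still unmeasured in this assay and carrying 2-chlorophenyl in place of 3-bromophenyl on a double-bonded chain carbon bound to a double-bonded chain carbon. Going by the values given here, one measured step bears on this place, the exchange of 2-methoxyphenyl for 3-bromophenyl (a 1.1-fold lower number from compound 1 to compound 2 (0.05 log units; within the scatter)). Among the compounds with values here, no measured compound carries 2-chlorophenyl, so this single step is thin support. No step beyond the scatter is expected in either direction, and the estimate is no change at the digits printed from compound 2 to compound 3 (within the scatter) as the expected size. For compound 3 the expected value is 260 umol/kg (range 140 umol/kg to 450 umol/kg).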

Compound 3, dose for half-maximal effect: 260 umol/kg
Beside the measured number, compound 3's estimate shows no gap at the digits printed; low and high end bracket the measured number.
By their numbers in this assay, from the lowest: compounds 2, 3 and 1 (each within the scatter of the next).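

In this assay, the exchange of 3-bromophenyl for 2-chlorophenyl on a double-bonded chain carbon bound to a double-bonded chain carbon gives no change at the digits printed from compound 2 to compound 3 (within the scatter); the halogen and its place on the aromatic ring differ together here, so the two cannot be read apart. Chloro in place of methoxy on an aromatic carbon gives a 1.1-fold lower number from compound 1 to compound 3 (0.05 log units; within the scatter), which makes compound 3 a second link to compound 1 and leaves all three aryl variants within the scatter of one another. Nothing measured speaks to why these compounds read alike.

Open, on these data alone, is whether an amine or a carboxylic acid on this aromatic ring would give a step beyond the scatter. Also open, as far as these compounds go, is whether an unsubstituted phenyl would read with these three compounds.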